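From 2,4-dimethylphenyl to 3-methylphenyl: a small swap

The compounds below may be only part of what the source reports. "The series", "measured", "known", "first", "only" and "open" are said of these compounds alone.

Medicinal chemists often change one small group on a molecule and then measure whether its activity shifts. Here, the test is a functional assay on MCF7 cells (Homo sapiens) for inhibition, read by MTT assay, with a stated time of 72 h; a lower number here means a stronger inhibitor, a higher number a weaker inhibitor. In this test, compound 1 `COc1cc2c(Oc3ccc(NC(=O)c4nn(-c5ccc(C)cc5C)cc(C)c4=O)cc3)ccnc2cc1OCCCCCCC(=O)NO` gives 2430 nM and compound 2 `COc1cc2c(Oc3ccc(NC(=O)c4nn(-c5ccccc5C)ccc4=O)cc3)ccnc2cc1OCCCCCC(=O)NO` gives 4360 nM. Compound 1 therefore stands level with compound 2, since repeated measurements of the same compound could differ this much.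

The next molecule, compound 3 `COc1cc2c(Oc3ccc(NC(=O)c4nn(-c5cccc(C)c5)cc(C)c4=O)cc3)ccnc2cc1OCCCCCCC(=O)NO`, keeps the rest of compound 1 but carries 3-methylphenyl in place of 2,4-dimethylphenyl on an aromatic nitrogen. Going by the values given here, no pair of measured compounds isolates this change, so the data offer no direct guide to its effect. Among the compounds with values here, the only hint is that compound 1 at 2430 nM and compound 2 at 4360 nM sit close together, so a large shift is not expected, and no step beyond the scatter is anticipated in either direction. The expected change is a 1.2-fold higher number from compound 1 to compound 3 (0.09 log units; within the scatter), an estimate that stays within the scatter. For compound 3, the estimated value is 3000 nM, with an expected range from 1200 nM to 7500 nM.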

Compound 3, half-maximal inhibitory concentration: 1680 nM
Compound 3: middle estimate off by 1.8-fold (0.25 log units), on the high side; measured number inside the range.
By their numbers in this assay, from the lowest: compounds 3, 1 and 2 (each within the scatter of the next, the first and the last beyond it).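

Going by these compounds alone, compound 1 and compound 3 differ in one place only, so this pair gives the first direct reading of the group on the aromatic nitrogen. In this assay, placing 3-methylphenyl there instead of 2,4-dimethylphenyl gives a 1.4-fold lower number from compound 1 to compound 3 (0.16 log units; within the scatter), which means the two compounds stand level in this test and the swap has no effect that can be told apart from ordinary variation between repeated measurements. Nothing measured here offers an explanation for this result, so the pair records what the change does in this cell test but not the reason.

Compound 2 differs from both of these compounds in more than one place, so it cannot show how any single change acts, and the methyl-bearing phenyl groups shown cover only a narrow range of what this position might hold. From the compounds shown here alone, whether the same level result would hold with a group of another kind on the aromatic nitrogen, such as a phenyl ring carrying an amine or a carboxylic acid, or a simple alkyl chain in place of the ring, remains open.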